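The source may report more compounds than this note shows. Statements on the series, on what has been measured and on what is new or still open speak of the compounds shown alone.

Of the compounds shown here, three built on a shared core have been measured, each carrying the same acylamino-substituted core and a benzyl group with a methoxy substituent, and differing only at the acidic end of the molecule. Compound 1 `CCCCC(CC)C(=O)Nc1ccc2ccn(Cc3ccc(C(=O)NS(=O)(=O)c4ccccc4C)cc3OC)c2c1` gives in a functional assay (trachea) for antagonist activity, with Cavia porcellus as the target (on this read-out higher numbers stand for higher potency (the scale is a negative logarithm) and lower numbers for lower potency), 8.9. For the measured compounds named here, compound 2 `CCCCC(CC)C(=O)Nc1ccc2ccn(Cc3ccc(C(=O)NS(=O)(=O)c4ccc(Cl)cc4)cc3OC)c2c1` gives in this assay 7.8, and the only single-site step among the measured compounds, a number 1.10 log units lower from compound 1 to compound 2 (beyond the scatter), is the step between them. Compound 3 `CCCCC(CC)C(=O)Nc1ccc2ccn(Cc3ccc(C(=O)C(C(=O)OC)S(=O)(=O)c4ccccc4)cc3OC)c2c1` gives in this assay 8.5; it stands second highest of the three numbers, below compound 1 and above compound 2, with both gaps beyond the scatter.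

Compound 4 `CCCCC(CC)C(=O)Nc1ccc2ccn(Cc3ccc(C(=O)C(C#N)S(=O)(=O)c4ccccc4)cc3OC)c2c1` is the compound still to be measured. Its change from compound 3 is cyano in place of methoxycarbonyl on a saturated chain carbon bound to a carbonyl carbon and a sulfonyl sulfur. Going by the values given here, no measured step touches this saturated chain carbon: the step from compound 1 to compound 2 concerns the aryl group on the sulfonyl sulfur and says nothing about what replaces the methoxycarbonyl group here. With nothing to lean on, the expected step of no change at the digits printed from compound 3 to compound 4 (within the scatter) is one that stays within the scatter. Compound 4 is therefore estimated to give in this assay about 8.5, with a range from 7.8 to 9.2.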

Compound 4, negative logarithm of the antagonist equilibrium constant: 8.1
Compound 4: middle estimate off by 0.40 log units, on the high side; the range from low to high includes it.
By their numbers in this assay, from the lowest: compounds 2 and 4 (each within the scatter of the next); then compound 3; then compound 1.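

In this assay, the saturated chain carbon bound to a carbonyl carbon and a sulfonyl sulfur now has a measured step of its own: cyano in place of methoxycarbonyl gives a number 0.40 log units lower from compound 3 to compound 4 (beyond the scatter) and shows that the number at this position depends on which of these two groups it carries. The exchange of the whole group on the carbonyl carbon reads differently against the two sulfonyl amino compounds, with cyano(phenylsulfonyl)methyl in place of ((2-methylphenyl)sulfonyl)amino giving a number 0.80 log units lower from compound 1 to compound 4 (beyond the scatter) while cyano(phenylsulfonyl)methyl in place of ((4-chlorophenyl)sulfonyl)amino gives a number 0.30 log units higher from compound 2 to compound 4 (within the scatter) and so separates compound 4 from only one of them. No measurement among these compounds speaks to why the cyano group reads as it does here.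

The compounds shown leave open how an amine, a carboxylic acid or a longer ester chain on this saturated chain carbon would compare with cyano and methoxycarbonyl. They also leave open whether 2-methylphenyl or 4-chlorophenyl on the sulfonyl sulfur would give the same step when this carbon carries cyano.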